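The source may hold more compounds than are shown below. What is called first, only, known or untested is meant among the compounds shown, and "the series" means these compounds.

Measured compounds:
compound 1, `NS(=O)(=O)c1ccc(-n2nc(Nc3ccccc3)c3c(=O)n(-c4ccccc4)c(Nc4ccccc4)nc32)cc1` — 60.2%
compound 2, `NS(=O)(=O)c1ccc(-n2nc(Nc3ccc([N+](=O)[O-])cc3)c3c(=O)n(-c4ccccc4)c(Nc4ccccc4)nc32)cc1` — 67%
compound 3, `O=c1c2c(Nc3ccc(Cl)cc3)nn(-c3ccccc3)c2nc(Nc2ccccc2)n1-c1ccccc1` — 47.6%

All three numbers come from a functional assay on the whole organism (strain Wistar albino) for inhibition, with Rattus norvegicus as the target, read by paw edema, with a stated time of 1 h, at a dose of 25 mg/kg by the oral route; a lower number here means less inhibition, a higher number more inhibition at the dose given (going by the name of the read-out). Compound 1 and compound 2 share a core and differ in one place: nitro in place of hydrogen on an aromatic carbon. The step that goes with this change is a number 6.8 percentage points higher from compound 1 to compound 2 (within the scatter), so the two are not told apart by this assay. Compound 3 carries a different core; the difference between the two cores is not broken down here, and compound 3 gives the lowest number of the three, with compound 1 the nearer of the other two.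

Compound 4, `O=c1c2c(Nc3ccc(Cl)cc3)nn(-c3ccc([N+](=O)[O-])cc3)c2nc(Nc2ccccc2)n1-c1ccccc1`, is not yet measured. It differs from compound 3 in one place: nitro in place of hydrogen on an aromatic carbon. Within the data shown here, the place where the nitro enters is described in the same words for both pairs, so this is taken as the same kind of change as the one from compound 1 to compound 2; cut one bond further out, the earlier pair also reads anilino to (4-nitrophenyl)amino, which the present pair does not.

Among the measured compounds shown here, for compound 4 the step from compound 3 is expected to be a number 4.4 percentage points higher from compound 3 to compound 4 (within the scatter), placed beside the earlier one, because a number 6.8 percentage points higher from compound 1 to compound 2 (within the scatter) is the only measured instance of this change and it stayed within the scatter. The expected value for compound 4 in this assay is 52%, with a likely range from 40% to 64%; this estimate rests on a single pair and a different core, so the range is kept wide.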

Compound 4, a percentage reported as inhibition, in the whole organism at one dose (the size of the read-out at that dose, not a potency): 39.6%
Estimate against measurement, compound 4: 12.4 percentage points above; measured number below the stated range.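

In this assay, nitro in place of hydrogen goes with a number 8 percentage points lower from compound 3 to compound 4 (within the scatter), and set beside the earlier pair, the same change does not carry over from one core to the other as a single fixed step: the same change on two cores in this assay, a number 6.8 percentage points higher (within the scatter) from compound 1 to compound 2 and a number 8 percentage points lower (within the scatter) from compound 3 to compound 4, 14.8 percentage points apart, beyond the scatter of two such steps. Each step on its own stays within the scatter, so neither pair separates its two compounds; only the gap between the two steps goes beyond it. This does not show what sets the steps apart, as the pairs differ both in core and in the group that takes the nitro, anilino to (4-nitrophenyl)amino in the earlier pair and phenyl to 4-nitrophenyl in the new one, and two pairs at a single dose and a single time support no general rule for the series.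

Open, from the compounds shown here alone, is whether the gap between the steps follows the core or the group that carries the nitro, a question that would need both nitro placements compared on one core. Also open, going by these compounds, is how other groups at the same place on the ring would behave, such as an amine, a nitrile or a carboxylic acid, and whether their steps would differ between the two cores.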